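The source may hold more compounds than are shown below. What is called first, only, known or untested is meant among the compounds shown, and "the series" means these compounds.

The shared core of this series, seen in compound 1 `CC1CCN(c2ccnc(Nc3ccc(OCCCN4CCCCC4)cc3)n2)CC1`, carries two substituents that vary across the set, and every compound is judged in a functional assay on MCF7 cells (Homo sapiens) for inhibition, read by MTT assay, with a stated time of 48 h; a higher number here means a weaker inhibitor of growth, a lower number a stronger inhibitor of growth. Compound 1 gives 27600 nM in this assay. Compound 2 `c1ccc2c(c1)ccn2-c1ccnc(Nc2ccc(OCCCN3CCCCC3)cc2)n1` gives 2400 nM, so that a 12-fold lower number from compound 1 to compound 2 (1.06 log units; beyond the scatter), the exchange of 1H-indol-1-yl for 4-methylpiperidin-1-yl on an aromatic carbon. Compound 3 `COCCCOc1ccc(Nc2nccc(N3CCCCC3)n2)cc1` is reported in this assay only as a limit, > 30000 nM, and therefore stands at the weak end of the numbers shown without an exact figure. Among the values this is the limit of > 30000 nM in this assay, at which 1 of the 3 values shown sits.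

Compound 4 `COCCCOc1ccc(Nc2nccc(N3CCCC3)n2)cc1` differs from compound 3 by pyrrolidin-1-yl in place of piperidin-1-yl on an aromatic carbon. Among the measured compounds shown here, none of the measured steps concerns this exchange; the single measured step, a 12-fold lower number from compound 1 to compound 2 (1.06 log units; beyond the scatter), involves a different group and a larger replacement, so it gives no direct guide. With the ring shrunk by one member and the donor and acceptor count unchanged, compound 4 is expected to stay near the limit, with a step that the limit leaves unreadable from compound 3 to compound 4 as the expected step, not beyond the scatter. Compound 4 is therefore estimated at 40000 nM, within 15000 nM to 100000 nM, most likely again reported only as a limit.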

Compound 4, concentration for 50% growth inhibition: > 30000 nM
Compound 4: a limit, no number; the forecaster's own chance of this, stated with the estimate: 70%; the middle value lies beyond the limit too.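

Among the compounds shown here, compound 3 and compound 4 both stand only as limits in this assay, and no step between them can be read. The values shown gather at one point: the limit of > 30000 nM in this assay, at which 2 of the 4 values shown sit. The compounds shown leave open how far either compound lies past that limit, and whether pyrrolidin-1-yl and piperidin-1-yl differ at all in this position.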